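Acyl sulfonamide chain extension and microsomal stability

This account rests on a few compounds, and the source may have more. Where it says the series, first, only, none or still open, it means among the compounds named here.

Compound 3 `CCS(=O)(=O)NC(=O)c1ccc(Nc2nc(NC3(c4ccc(Cl)cc4)CC3)nc(OCC(F)(F)F)n2)cc1` is the point of departure. In an ADME assay on microsomes from liver (Rattus norvegicus) for metabolic stability, with a stated time of 10 min (a higher number here means that more of the compound is left, a lower number that less of the compound is left), compound 3 gives 85%. Two measured neighbours carry a substituent on the same chain carbon: compound 1 `CC(C)(C)NC(=O)NCCS(=O)(=O)NC(=O)c1ccc(Nc2nc(NC3(c4ccc(Cl)cc4)CC3)nc(OCC(F)(F)F)n2)cc1` gives 93% in this assay, and compound 2 `CC(C)C(=O)NCCS(=O)(=O)NC(=O)c1ccc(Nc2nc(NC3(c4ccc(Cl)cc4)CC3)nc(OCC(F)(F)F)n2)cc1` gives 84%. Compound 3 thus stands second of the three numbers, nearest to compound 2 and furthest from compound 1, with both gaps inside the usual scatter.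

Compound 4 `CC(=O)NCCS(=O)(=O)NC(=O)c1ccc(Nc2nc(NC3(c4ccc(Cl)cc4)CC3)nc(OCC(F)(F)F)n2)cc1` differs from compound 3 in one place: acetamido in place of hydrogen on a saturated chain carbon, two bonds along the chain from a sulfonyl sulfur.

Within the data shown here, the steps that bear on this change are the reverse reads of a number 8 percentage points lower from compound 1 to compound 3 (within the scatter) and a number 1 percentage points higher from compound 2 to compound 3 (within the scatter), both of which remove a larger acylamino or carbamoylamino group from that chain carbon without a shift beyond the scatter. Likewise a number 9 percentage points lower from compound 1 to compound 2 (within the scatter) exchanges the group on the carbonyl carbon without a shift beyond the scatter. Adding the smaller acetamido group is therefore expected to leave this assay essentially unchanged, with the step of a number 1 percentage points higher from compound 3 to compound 4 (within the scatter) expected to stay inside the scatter. For compound 4 the estimate in this assay is 86%, expected to fall between 76% and 95%.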

Compound 4, percent of the compound remaining: 100%
Compound 4: middle estimate off by 14 percentage points, on the low side; the whole stated range lies below it.
By their numbers in this assay, from the lowest: compounds 2, 3, 1 and 4 (each within the scatter of the next, the first and the last beyond it).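

In this assay, among these compounds, acetamido in place of hydrogen on the saturated chain carbon, two bonds along the chain from a sulfonyl sulfur, gives the first step at this position that lies beyond the scatter: a number 15 percentage points higher from compound 3 to compound 4 (beyond the scatter). The outcome at this position therefore depends on the group on the carbonyl carbon, since the step of a number 1 percentage points higher from compound 2 to compound 3 (within the scatter) stays within the scatter, while methyl in place of isopropyl gives a number 16 percentage points higher from compound 2 to compound 4 (beyond the scatter) and methyl in place of (tert-butyl)amino gives a number 7 percentage points higher from compound 1 to compound 4 (within the scatter), which stays within the scatter. The compounds shown offer no independent measurement that accounts for the step from hydrogen to acetamido.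

Still open, on these data alone, is whether a free amine or a carboxylic acid on the same chain carbon, or a longer chain carrying the acetamido group, would keep the number of compound 4 or return to that of compound 3. Also open, as far as these compounds go, is whether a cyclopropyl or a methylamino group on the carbonyl carbon would read with compound 4 or with compound 2.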